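The compounds below may be only part of what the source reports. "The series", "measured", "known", "first", "only" and "open" are said of these compounds alone.

Compound 1, `O=C1C(=Cc2ccc(O)cc2)C(=O)N(c2ccc(Cl)cc2)N1c1ccc(Cl)cc1`: in a functional assay on SMMC-7721 cells (Homo sapiens) for cytotoxicity, read by MTT assay, with a stated time of 72 h (on this read-out lower numbers stand for stronger inhibition and higher numbers for weaker inhibition), compound 1 gives 20600 nM.
Compound 2, `COc1cccc(C=C2C(=O)N(c3ccc(Cl)cc3)N(c3ccc(Cl)cc3)C2=O)c1O`: compound 2 gives 64900 nM.
Compound 3, `O=C1C(=Cc2ccc(Cl)cc2Cl)C(=O)N(c2ccc(Cl)cc2)N1c1ccc(Cl)cc1`: compound 3 is reported only at > 128000 nM, a limit of the assay (the limit of > 128000 nM in this assay, at which 1 of the 3 values shown sits).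

Compound 1 has the lowest of the two numbers; the nearest is compound 2, with a 3.2-fold higher number from compound 1 to compound 2 (0.50 log units; beyond the scatter). Compound 4, `O=C1C(=Cc2ccco2)C(=O)N(c2ccc(Cl)cc2)N1c1ccc(Cl)cc1`, differs from compound 1 by furan-2-yl in place of 4-hydroxyphenyl on a double-bonded chain carbon bound to a double-bonded ring carbon. Among the measured compounds shown here, the steps that bear on this both replace the same 4-hydroxyphenyl: a 3.2-fold higher number from compound 1 to compound 2 (0.50 log units; beyond the scatter) and an at least 6.2-fold higher number from compound 1 to compound 3 (0.79 log units; beyond the scatter), each giving a higher number. Since furan-2-yl also removes that group, a modestly higher number is expected for compound 4. Compound 4 is estimated at 70000 nM, with a range from 25000 nM to 200000 nM. This estimate means a 3.4-fold higher number from compound 1 to compound 4 (0.53 log units; beyond the scatter).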

Compound 4, half-maximal inhibitory concentration: 19500 nM
The estimate for compound 4 lay 3.6-fold (0.56 log units) above the measured number, and the stated range ends above it.
By their numbers in this assay, from the lowest: compounds 4 and 1 (each within the scatter of the next); then compound 2. At a limit, above all of these: compound 3.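

The 4-hydroxyphenyl group can be replaced at this position with no change beyond the scatter: a 1.1-fold lower number from compound 1 to compound 4 (0.02 log units; within the scatter). The hydrogen-bond donor of compound 1 and its six-membered ring are therefore not needed to keep this number, and compound 4 goes against the rise seen with the other two replacements, showing a 3.3-fold lower number from compound 2 to compound 4 (0.52 log units; beyond the scatter) and an at least 6.5-fold lower number from compound 3 to compound 4 (0.81 log units; beyond the scatter). Compound 3 stands only at a limit of the assay: the limit of > 128000 nM in this assay, at which 1 of the 4 values shown sits.

Going by these compounds, whether a thiophen-2-yl or pyridin-3-yl ring would match furan-2-yl on this chain carbon remains open. So does whether a ring is needed here at all, which a methyl group would test.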